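The source may hold more compounds than are shown below. What is called first, only, known or untested is meant among the compounds shown, and "the series" means these compounds.

Working notes on the series. Two compounds share the core and differ only in the aryl group on the sulfonyl sulfur. Compound 1 `CN1CCN(c2ccc3[nH]nc(S(=O)(=O)c4ccccc4Cl)c3c2)CC1` carries a 2-chlorophenyl there; in an assay on HeLa cells for displacement of a labelled ligand from 5-hydroxytryptamine receptor 6 (Homo sapiens) (a lower number here means a stronger inhibitor, a higher number a weaker inhibitor), compound 1 gives 4 nM. Compound 2 `CN1CCN(c2ccc3[nH]nc(S(=O)(=O)c4ccc(Cl)cc4)c3c2)CC1` carries a 4-chlorophenyl; in this assay compound 2 gives 8.1 nM. Among the compounds with values here, the single step between them, a 2.0-fold higher number from compound 1 to compound 2 (0.31 log units; beyond the scatter), is the only measured step in the set. Compound 2 thus holds the higher of the two numbers, with compound 1 the nearer and only neighbour.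

Compound 3 `CN1CCN(c2ccc3[nH]nc(S(=O)(=O)c4cccs4)c3c2)CC1` has not yet been run. Against compound 2 the change is thiophen-2-yl in place of 4-chlorophenyl on a sulfonyl sulfur. Within the data shown here, no measured step bears directly on this exchange; the one known step concerns the position of a chlorine on a phenyl, not a swap of the ring itself, and that step was modest. With nothing larger in hand, no movement beyond the scatter in this assay is expected, and the estimated step from compound 2 is a 1.0-fold lower number from compound 2 to compound 3 (0.01 log units; within the scatter). Compound 3 is expected to give about 8 nM, within 3 nM to 25 nM, pending the measurement.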

Compound 3, inhibition constant: 7.8 nM
Estimate against measurement, compound 3: 1.0-fold (0.01 log units) above; the measured number falls inside the stated range.
By their numbers in this assay, from the lowest: compounds 1, 3 and 2 (each within the scatter of the next, the first and the last beyond it).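

In this assay the aryl ring itself can be exchanged on the sulfonyl sulfur, not only the chlorine moved around a phenyl: the thiophen-2-yl of compound 3 gives a 1.0-fold lower number from compound 2 to compound 3 (0.02 log units; within the scatter) and, against the other chlorinated analogue, a 2.0-fold higher number from compound 1 to compound 3 (0.29 log units; within the scatter) as the second reading. A five-membered aromatic ring with 1 hetero atom, carrying no chlorine, therefore stands within the scatter of both the 4-chlorophenyl and the 2-chlorophenyl compounds, although those two remain separated from each other by a step beyond the scatter. Within the data shown here, the position so far accepts a change of ring size and ring atoms with no step beyond the scatter, and no supporting data on the origin of this result are at hand.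

Going by these compounds, all three compounds keep an aromatic ring directly on the sulfonyl sulfur, so it remains open how the number responds to a saturated group there, such as a cyclohexyl or a longer alkyl chain. Equally open, on these data alone, is the effect on the number of a ring bearing an amine or a carboxylic acid at this position.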